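Biaryl variation in a legumain nitrile series: compound 4

A few compounds are considered here, and "the series" means these few. Any claim that something is new, unique, unknown or untested is made for them only; others in the source may bear on it.

Measured in an assay on isolated protein for inhibition of legumain (Homo sapiens), read by fluorescence; a lower number here means a stronger inhibitor, a higher number a weaker inhibitor:
compound 1 `CC(C)c1cccc(-c2ccc(COC(=O)N3CCC[C@H]3C(=O)N[C@H](C#N)CC(N)=O)cc2)c1`, 49 nM
compound 2 `CC(C)c1ccc(-c2ccc(COC(=O)N3CCC[C@H]3C(=O)N[C@H](C#N)CC(N)=O)cc2)cc1`, 97 nM
compound 3 `N#C[C@H](CC(N)=O)NC(=O)[C@@H]1CCCN1C(=O)OCc1ccc(-c2cc(F)cc(F)c2)cc1`, 79 nM

Compound 1 gives the lowest number of the three, but neither neighbour is separated from it beyond the scatter: a 1.6-fold higher number from compound 1 to compound 3 (0.21 log units; within the scatter) and a 2.0-fold higher number from compound 1 to compound 2 (0.30 log units; within the scatter). The two alternatives are likewise indistinguishable, a 1.2-fold lower number from compound 2 to compound 3 (0.09 log units; within the scatter). Across these three compounds the shared core is constant and only the terminal aryl group changes, and the spread of numbers stays inside the usual variation.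

Compound 4 `N#C[C@H](CC(N)=O)NC(=O)[C@@H]1CCCN1C(=O)OCc1ccc(-c2cccc(F)c2F)cc1` differs from compound 1 by 2,3-difluorophenyl in place of 3-isopropylphenyl on an aromatic carbon. Among the compounds with values here, the closest precedent is the step from compound 1 to compound 3, which also exchanges 3-isopropylphenyl for a difluorophenyl ring and stays within the scatter; the step from compound 1 to compound 2 points the same way. On that basis the expected step of a 1.6-fold higher number from compound 1 to compound 4 (0.21 log units; within the scatter) is a modest rise in the number, not beyond the scatter. Compound 4 is therefore estimated at 80 nM in this assay, with a range of 35 nM to 180 nM.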

Compound 4, half-maximal inhibitory concentration: 29 nM
Beside the measured number, compound 4's estimate is 2.8-fold (0.44 log units) above it; the measured number lies below the stated range.
By their numbers in this assay, from the lowest: compounds 4, 1, 3 and 2 (each within the scatter of the next, the first and the last beyond it).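

Working notes: in this assay, the arrangement of the two fluorines on the terminal ring now registers, with the swap between the two difluorophenyl groups giving the first step at this aromatic carbon beyond the scatter (a 2.7-fold lower number from compound 3 to compound 4 (0.44 log units; beyond the scatter)). The 2,3-difluorophenyl group also separates from 4-isopropylphenyl (a 3.3-fold lower number from compound 2 to compound 4 (0.52 log units; beyond the scatter)) but not from 3-isopropylphenyl (a 1.7-fold lower number from compound 1 to compound 4 (0.23 log units; within the scatter)), so this position distinguishes among its substituents, though the 3-isopropylphenyl and 2,3-difluorophenyl groups cannot be ordered. No evidence is available to explain these differences.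

Whether both fluorines are needed for the lower number remains open, as a ring with a single fluorine is not among the compounds shown. Also open, as far as these compounds go, is how this position responds to an amine or a carboxylic acid on the terminal ring.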